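Side-chain change on compound 3

The compounds below may be only part of what the source reports. "The series", "measured", "known", "first", "only" and "open" are said of these compounds alone.

In a functional assay on LoVo cells (Homo sapiens) for cytotoxicity, read by colorimetric assay and MTT assay (on this read-out lower numbers stand for stronger inhibition and higher numbers for weaker inhibition), compound 1 `COc1cc(OC)c2cc(-c3ccccc3)c(O)nc2c1` gives 10000 nM and compound 2 `COc1ccc(-c2cc3c(OC)ccc(OC)c3nc2O)cc1` gives 10000 nM. Compound 3 `CCN(CC)C(=O)Cn1c(=O)c(-c2ccc(OC)cc2)cc2c(OC)cc(OC)cc21` gives 10000 nM, level with both others, with no difference beyond the scatter.

Compound 4 `COc1ccc(-c2cc3c(OC)cc(OC)cc3n(CCC#N)c2=O)cc1` carries cyanomethyl in place of diethylcarbamoyl on a saturated chain carbon bound to an aromatic nitrogen. Among the measured compounds shown here, no measured pair differing in one place is available to size this change. With compound 3 at 10000 nM and no spread among the three measured values, no step beyond the scatter is expected in this assay. The expected step of a 1.3-fold lower number from compound 3 to compound 4 (0.10 log units; within the scatter) is small, with any larger move more likely toward stronger inhibition. For compound 4 the estimated value is 8000 nM, with an expected range of 2000 nM to 15000 nM.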

Compound 4, half-maximal inhibitory concentration: 10000 nM
Compound 4: the middle estimate sits 1.3-fold (0.10 log units) below what was measured; low and high end bracket the measured number.
By their numbers in this assay, from the lowest: compounds 1, 2, 3 and 4 (each within the scatter of the next).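

In this assay, among the compounds shown here, cyanomethyl in place of diethylcarbamoyl on a saturated chain carbon bound to an aromatic nitrogen gives no change at the digits printed from compound 3 to compound 4 (within the scatter) and supplies the first step between compounds differing in one place. Within this pair, losing the diethylcarbamoyl carbonyl and bringing in a nitrile leaves the read-out level. No supporting measurement explains this result. Going by these compounds, whether an amine or a carboxylic acid at this place would move the number remains open. So does the effect of a longer chain carrying the nitrile.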